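Bromo in place of fluoro: compound 1 to compound 3

The source may hold more compounds than are shown below. What is called first, only, known or untested is meant among the compounds shown, and "the series" means these compounds.

Compound 1 `Fc1ccccc1NC(=S)N/N=C/c1ccc2ccccc2n1` was tested in a functional assay on HL-60 cells (Homo sapiens) for antiproliferative activity, read by sulforhodamine B assay, with a stated time of 72 h; on this read-out lower numbers stand for stronger inhibition and higher numbers for weaker inhibition. In this assay compound 1 gives > 100000 nM, which is a limit of the assay rather than a number. Compound 2 `NC(=S)N/N=C/c1cnc2ccccc2n1` was measured in the same way. In this assay compound 2 likewise gives > 100000 nM, again a limit and not a number. Going by the values given here, compound 1 thus stands at the limit, as does the only other value shown, and nothing places either compound on the scale: the limit of > 100000 nM in this assay, at which 2 of the 2 values shown sit. Among the compounds with values here, no step between measured compounds that differ in one place is available.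

Compound 3 `S=C(N/N=C/c1ccc2ccccc2n1)Nc1ccccc1Br` is yet to be measured. It differs from compound 1 by bromo in place of fluoro on an aromatic carbon. With both values in hand sitting at the limit, no step beyond the scatter is expected from this change, and the likeliest outcome is that compound 3 is also reported only as a limit. For compound 3 the expected step reads a number no higher from compound 1 to compound 3 (the limit leaves the size open). Compound 3 is estimated at 100000 nM in this assay, within 30000 nM to 300000 nM.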

Compound 3, half-maximal inhibitory concentration: > 100000 nM
Compound 3 gave a limit, no number; the forecaster's own chance of this, stated with the estimate: 75%; the middle value lies on the limit itself.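

Compound 1 and compound 3 are both reported only as limits in this assay, so no step can be read for bromo in place of fluoro: the limit of > 100000 nM in this assay, at which 3 of the 3 values shown sit.

The compounds shown leave open where any of them lies on the scale of this assay, and whether 2-fluorophenyl and 2-bromophenyl differ at all.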